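Trimming a Ring to a Branch on the Shared Core

The compounds below may be only part of what the source reports. "The series", "measured", "known", "first", "only" and "open" are said of these compounds alone.

Compound 1, `O=C(O)c1ccccc1-c1ccc(CCc2ncc(CC3CCCC3)[nH]2)cc1`: 7.9 nM
Compound 2, `COc1ccc(Cc2cnc(CCc3ccc(-c4ccccc4C(=O)O)cc3)[nH]2)cc1`: 513 nM

Both were tested in an in vitro functional assay on cells for agonist activity at Bombesin receptor subtype-3 (Mus musculus), read by luminescence and calcium flux; a higher number here means that more compound is needed for the effect, a lower number that less compound is needed. Among the compounds with values here, compound 1 has the lowest of the two numbers; the one measured step is a 65-fold higher number from compound 1 to compound 2 (1.81 log units; beyond the scatter). Compound 3, `CC(C)(C)c1cnc(CCc2ccc(-c3ccccc3C(=O)O)cc2)[nH]1`, has not been measured. It differs from compound 1 in one place: tert-butyl in place of cyclopentylmethyl on an aromatic carbon. Within the data shown here, no measured step shows this exact swap; the only step in hand concerns a different change and is a loose guide at best. For compound 3 a modest rise is expected, a 3.8-fold higher number from compound 1 to compound 3 (0.58 log units; beyond the scatter). Compound 3 is therefore estimated at 30 nM, between 8 nM and 150 nM.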

Compound 3, half-maximal effective concentration: 2750 nM
For compound 3 the middle estimate is 92-fold (1.96 log units) below the measured one; the whole stated range lies below it.
By their numbers in this assay, from the lowest: compound 1; then compound 2; then compound 3.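

Trimming cyclopentylmethyl to tert-butyl on this aromatic carbon gives a 350-fold higher number from compound 1 to compound 3 (2.54 log units; beyond the scatter) in this assay, so this position does not accept the swap without a large change. Tert-butyl also compares poorly with 4-methoxybenzyl, with a 5.4-fold higher number from compound 2 to compound 3 (0.73 log units; beyond the scatter), and so both ring-bearing groups shown give lower numbers than the branched group. Nothing available explains these differences. From the compounds shown here alone, it remains open whether the ring or the saturated chain carbon matters more: an isobutyl group has that chain carbon without a ring, while a cyclopentyl group bound directly to the aromatic carbon has the ring without it.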